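The source may report more compounds than this note shows. Statements on the series, on what has been measured and on what is new or still open speak of the compounds shown alone.

Measured compounds in the series:

compound 1 `CC(C)C[C@H](NC(=O)c1cc2ccccc2o1)C(=O)N[C@H]1CCN(Cc2ccc(OCCCN(C)C)cc2)C1`: 158 nM
compound 2 `CC(C)C[C@H](NC(=O)c1ccc(Br)cc1)C(=O)N[C@H]1CCN(Cc2ccc(OCCCN(C)C)cc2)C1`: 200 nM

Both numbers come from an assay on HEK293 cells for binding affinity to Urotensin-2 receptor (Homo sapiens), read by radioligand binding; a lower number here means a stronger inhibitor, a higher number a weaker inhibitor. Going by the values given here, compound 2 stands alongside compound 1: the step of a 1.3-fold higher number from compound 1 to compound 2 (0.10 log units; within the scatter) leaves the two indistinguishable, and there is no other measured compound to place it against.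

Compound 3 `CC(C)C[C@H](NC(=O)c1ccncc1)C(=O)N[C@H]1CCN(Cc2ccc(OCCCN(C)C)cc2)C1` is not yet measured in this assay. It differs from compound 2 at the same position that separates compound 1 from compound 2: pyridin-4-yl in place of 4-bromophenyl on a carbonyl carbon. Among the compounds with values here, the only measured step that bears on this change is the one from compound 1 to compound 2, an exchange of the aryl group on the carbonyl carbon, and that step was a 1.3-fold higher number from compound 1 to compound 2 (0.10 log units; within the scatter). On that single precedent a change at this position is expected to move the number little, so for compound 3 the expected step is a 1.3-fold higher number from compound 2 to compound 3 (0.10 log units; within the scatter), not beyond the scatter. Compound 3 is therefore estimated at 250 nM in this assay, within a range of 80 nM to 800 nM.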

Compound 3, inhibition constant: 2000 nM
The estimate for compound 3 lay 8.0-fold (0.90 log units) below the measured number, outside the stated range (above it).
By their numbers in this assay, from the lowest: compounds 1 and 2 (each within the scatter of the next); then compound 3.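

In this assay this position does respond to the group on the carbonyl carbon: the exchange of 4-bromophenyl for pyridin-4-yl gives a 10-fold higher number from compound 2 to compound 3 (1.00 log units; beyond the scatter) and the exchange of 1-benzofuran-2-yl for pyridin-4-yl gives a 13-fold higher number from compound 1 to compound 3 (1.10 log units; beyond the scatter), so the earlier indistinguishable pair did not describe the position as a whole. Pyridin-4-yl brings a ring nitrogen and a hydrogen-bond acceptor, and the same exchange removes the bromine, so these differences arrive together in compound 3. Nothing available explains the size of this step.

From the compounds shown here alone, whether the step follows the ring nitrogen or the missing bromine remains open. Unsubstituted phenyl, 4-chlorophenyl or pyridin-3-yl on the same carbonyl carbon would help separate the two.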